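From Methoxycarbonyl to 3-Carboxyphenyl on the Shared Core

The source may hold more compounds than are shown below. What is called first, only, known or untested is meant among the compounds shown, and "the series" means these compounds.

Three compounds have been measured in an assay on microsomes from brain for inhibition of Fatty-acid amide hydrolase 1 (Rattus norvegicus), read by fluorescence and HPLC, with a stated time of 60 min; a lower number here means a stronger inhibitor, a higher number a weaker inhibitor:

Compound 1 `CCCCCCCCc1ccc(OCC(=O)Cn2nnnc2-c2ccc(Cl)cc2)cc1` gives 130 nM.
Compound 2 `CCCCCCCCc1ccc(OCC(=O)Cn2nnnc2-c2ccc(S(=O)(=O)N(C)C)cc2)cc1` gives 1400 nM.
Compound 3 `CCCCCCCCc1ccc(OCC(=O)Cn2nnnc2C(=O)OC)cc1` gives 1000 nM.

Compound 3 holds the second highest of the three numbers. Its nearest neighbour is compound 2, and the step of a 1.4-fold lower number from compound 2 to compound 3 (0.15 log units; within the scatter) lies within the scatter. Its furthest neighbour is compound 1, and the step of a 7.7-fold higher number from compound 1 to compound 3 (0.89 log units; beyond the scatter) lies beyond the scatter.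

Compound 4 `CCCCCCCCc1ccc(OCC(=O)Cn2nnnc2-c2cccc(C(=O)O)c2)cc1` is the next compound. Compared with compound 3 it carries 3-carboxyphenyl in place of methoxycarbonyl on an aromatic carbon. Among the compounds with values here, two measured steps bear on this change, since both replace an aromatic group on the shared core with methoxycarbonyl. The step of a 7.7-fold higher number from compound 1 to compound 3 (0.89 log units; beyond the scatter) is modest and raised the number; the step of a 1.4-fold lower number from compound 2 to compound 3 (0.15 log units; within the scatter) stayed within the scatter. Compound 4 returns an aromatic group to that position, so a lower number than compound 3 is expected, but the two precedents disagree, so only a small step is expected, a 1.7-fold lower number from compound 3 to compound 4 (0.22 log units; within the scatter). Compound 4 is therefore estimated at 600 nM in this assay, with a range from 150 nM to 3000 nM.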

Compound 4, half-maximal inhibitory concentration: 1800 nM
Estimate against measurement, compound 4: 3.0-fold (0.48 log units) below; low and high end bracket the measured number.
By their numbers in this assay, from the lowest: compound 1; then compounds 3, 2 and 4 (each within the scatter of the next).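

Measured in this assay compound 4 shows that an aromatic ring at this position does not by itself bring back the number of compound 1: the change from methoxycarbonyl to 3-carboxyphenyl gives a 1.8-fold higher number from compound 3 to compound 4 (0.26 log units; within the scatter) and a 1.3-fold higher number from compound 2 to compound 4 (0.11 log units; within the scatter) adds a second step of the same standing. Against the 4-chlorophenyl group the same replacement gives a 14-fold higher number from compound 1 to compound 4 (1.14 log units; beyond the scatter) so among these four compounds compound 1 alone stands apart as the strongest inhibitor, and what the ring carries matters more here than the presence of the ring. Nothing shown here accounts for this result.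

The compounds shown leave open how a plain phenyl group would read at this position. They also leave open whether a methyl ester in place of the carboxylic acid of compound 4 would move the number.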